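The source may report more compounds than this note shows. Statements on the series, on what has been measured and on what is new or still open speak of the compounds shown alone.

Compound 1, `O=C(/C=C\Nc1ccc(F)cc1)c1nc(-c2ccc(F)cc2)n2ccccc12`: in a functional assay on BT-474 cells (Homo sapiens) for cytotoxicity, read by MTT assay, with a stated time of 48 h (on this read-out lower numbers stand for stronger inhibition and higher numbers for weaker inhibition), compound 1 gives 16900 nM.
Compound 2, `Cc1cc2cc(N/C=C\C(=O)c3nc(-c4ccc(F)cc4)n4ccccc34)ccc2[nH]1`: compound 2 reaches only a limit of the assay, > 30000 nM.

Among the values shown, compound 1 holds the only true number; the other is the limit of > 30000 nM in this assay, at which 1 of the 2 values shown sits. The step from compound 1 to compound 2, which puts 2-methyl-1H-indol-5-yl in place of 4-fluorophenyl on the amine nitrogen, reads an at least 1.7-fold higher number from compound 1 to compound 2 (0.24 log units; that floor lies within the scatter).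

Compound 3, `COc1ccc(-c2nc(C(=O)/C=C\Nc3ccc(F)cc3)c3ccccn23)cc1`, is not yet measured. It differs from compound 1 by methoxy in place of fluoro on an aromatic carbon, so that 4-fluorophenyl becomes 4-methoxyphenyl on the shared core, a different place from the change between compound 1 and compound 2. For the measured compounds named here, no measured step therefore covers this change, and the one step known is itself within the scatter. For compound 3 in this assay a step of a 1.1-fold lower number from compound 1 to compound 3 (0.05 log units; within the scatter) is expected, not beyond the scatter, with an estimate of 15000 nM, between 5000 nM and 45000 nM.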

Compound 3, half-maximal inhibitory concentration: > 30000 nM
Compound 3: only a limit was reported; the forecaster's own chance of this, stated with the estimate: 25%; at least 2.0-fold (0.30 log units) between middle value and limit.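

Placing methoxy where fluoro sat, on the aromatic carbon para to a large group, is the first change shown at this position, and in this assay it gives an at least 1.7-fold higher number from compound 1 to compound 3 (0.24 log units; that floor lies within the scatter). Compound 3 reaches only a limit of the assay, > 30000 nM, which is not a true number. This change therefore shows no gain over compound 1, but whether it has any real effect cannot be told, because the reading stops at the same limit as compound 2: the limit of > 30000 nM in this assay, at which 2 of the 3 values shown sit.

Still open, going by these compounds, is whether any other group at this position, such as an amine, a carboxylic acid or a longer alkoxy chain, would give a number clearly lower than that of compound 1. Also open, on these data alone, is whether a smaller change on the amine nitrogen, such as chloro in place of fluoro, would shift the number.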